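The source may report more compounds than this note shows. Statements on the series, on what has been measured and on what is new or still open speak of the compounds shown alone.

Compound 1 `CCCCCCCCC#Cc1cn(CCC(COC(C)=O)COC(C)=O)c(=O)n(C(=O)c2ccccc2)c1=O` gives 32400 nM in a functional assay on HeLa cells (Homo sapiens) for antiproliferative activity, read by MTT assay, with a stated time of 72 h; a lower number here means a stronger inhibitor, a higher number a weaker inhibitor.
Compound 2 `CC(=O)OCC(CCn1cc(C#CCCCCl)c(=O)n(C(=O)c2ccccc2)c1=O)COC(C)=O` gives 52800 nM in this assay.
Compound 3 `CCCCCCCCC#Cc1cn(CCC(CO)CO)c(=O)[nH]c1=O` gives 58900 nM in this assay.

Compounds 1 and 2 share one core and differ in a single place: chloro in place of pentyl on a saturated chain carbon, three bonds along the chain from a triple-bonded carbon. In this assay this change produced a 1.6-fold higher number from compound 1 to compound 2 (0.21 log units; within the scatter), so the two numbers cannot be told apart with confidence. Compound 3 carries a different core from compound 1; how the two cores differ is not broken down here. Its value in this assay lies within the scatter of both compound 2 and compound 1, so no ordering among the three measured compounds can be claimed.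

Compound 4 `O=c1[nH]c(=O)n(CCC(CO)CO)cc1C#CCCCCl` has not yet been measured in this assay. It is built from compound 3 by chloro in place of pentyl on a saturated chain carbon, three bonds along the chain from a triple-bonded carbon, which is the same change that leads from compound 1 to compound 2, made at the same place on the chain. Within the data shown here, the only guide to its effect is the single earlier pair, where the step of a 1.6-fold higher number from compound 1 to compound 2 (0.21 log units; within the scatter) stayed within scatter. On that basis the step from compound 3 to compound 4 is expected to be a 1.5-fold higher number from compound 3 to compound 4 (0.18 log units; within the scatter), a small shift toward a higher number. Compound 4 is therefore estimated at 90000 nM in this assay, with a plausible range from 45000 nM to 200000 nM. Since all three measured numbers are already high, there is a real chance that compound 4 is reported only as a limit rather than as a number.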

Compound 4, half-maximal inhibitory concentration: > 100000 nM
Compound 4 ended at the assay's limit; the forecaster's own chance of this, stated with the estimate: 25%; at least 1.1-fold (0.04 log units) between middle value and limit.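

In this assay compound 4 gives > 100000 nM, which is a limit of the assay and not a number. On the second core, chloro in place of pentyl gives an at least 1.6-fold higher number from compound 3 to compound 4 (0.22 log units; that floor lies within the scatter), so the result is compatible with the change carrying over from one core to the other, but it does not establish that it does, as neither reading of the change lies beyond the scatter. Nor does it show whether the change has the same size on both cores, because one of the two steps is only a floor: the same change on two cores in this assay, a 1.6-fold higher number (0.21 log units; within the scatter) from compound 1 to compound 2 and an at least 1.6-fold higher number (0.22 log units; that floor lies within the scatter) from compound 3 to compound 4; the limit leaves it open whether they differ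

The compounds shown leave open how other groups at this place on the chain would read in this assay, for example an amine, a carboxylic acid or a longer chain ending in chloro, and whether any of them would bring a value clearly apart from the others. Among these compounds, they also leave open which part of the difference between the core of compound 1 and the core of compound 3 matters, as no pair here separates that difference into single changes.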